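Swapping the Hydrazone Aryl Group: From Halogens to Dimethylamino

This account rests on a few compounds, and the source may have more. Where it says the series, first, only, none or still open, it means among the compounds named here.

compound 1, `Nc1nc(N/N=C/c2cccc(OCc3ccccc3)c2)nc2c1ncn2[C@@H]1O[C@H](CO)[C@@H](O)[C@H]1O`: 13 nM
compound 2, `Nc1nc(N/N=C/c2ccc(N(c3ccccc3)c3ccccc3)cc2)nc2c1ncn2[C@@H]1O[C@H](CO)[C@@H](O)[C@H]1O`: > 10000 nM
compound 3, `Nc1nc(N/N=C/c2ccc(Cl)c(C(F)(F)F)c2)nc2c1ncn2[C@@H]1O[C@H](CO)[C@@H](O)[C@H]1O`: > 10000 nM

In an assay on CHO-K1 cells for displacement of a labelled ligand from adenosine receptor A1 (Homo sapiens), read by scintillation counting, with a stated time of 60 min (on this read-out lower numbers stand for stronger inhibition and higher numbers for weaker inhibition), compound 1 gives 13 nM. For compound 2 the assay reports only a limit, > 10000 nM. For compound 3 the reading is likewise a limit, > 10000 nM, placing it at the limit of > 10000 nM in this assay, at which 2 of the 3 values shown sit, so no true number exists for it. Compound 4, `CN(C)c1ccc(/C=N/Nc2nc(N)c3ncn([C@@H]4O[C@H](CO)[C@@H](O)[C@H]4O)c3n2)cc1`, differs from compound 3 by 4-(dimethylamino)phenyl in place of 4-chloro-3-(trifluoromethyl)phenyl on a carbon with a double bond to nitrogen. For the measured compounds named here, no measured pair shows this change directly, so its direction rests only on the three values shown. A gain beyond the scatter is expected, an at least 5.0-fold lower number from compound 3 to compound 4 (0.69 log units; beyond the scatter), because compound 1 gives 13 nM and shows the shared core can bind strongly. Compound 4 is estimated at about 2000 nM, within 150 nM to 10000 nM, with a real chance that only a limit is reported again.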

Compound 4, inhibition constant: > 10000 nM
Compound 4 ended at the assay's limit; the forecaster's own chance of this, stated with the estimate: 40%; middle value at least 5.0-fold (0.69 log units) away from the limit.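

Compound 3 and compound 4 both give only a limit, so no step between them can be read: the limit of > 10000 nM in this assay, at which 3 of the 4 values shown sit.

The compounds shown leave open how strongly compound 3 and compound 4 truly bind, and whether this swap changes binding at all.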